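The source may report more compounds than this note shows. Statements on the series, on what has been measured and on what is new or still open speak of the compounds shown alone.

In a functional assay on A549 cells (Homo sapiens) for cytotoxicity, read by MTT assay, with a stated time of 72 h (a lower number here means a stronger inhibitor, a higher number a weaker inhibitor), compound 1 (`COc1cccc(/C=C2\CCC/C(=C\c3cccc(Br)c3)C2=O)c1OC`) gives > 20000 nM, which is a limit and not a number. The same holds for compound 2 (`COc1cccc(/C=C2\CCC/C(=C\c3cccc(Cl)c3Cl)C2=O)c1OC`), which gives > 20000 nM, also a limit. Against these, compound 3 (`COc1cccc(/C=C2\CCC/C(=C\c3cc(Cl)cc(Cl)c3)C2=O)c1OC`) gives 12500 nM, the only actual number in the set.

The next analogue, compound 4 (`COc1cccc(/C=C2\CCC/C(=C\c3ccc(O)c(O)c3)C2=O)c1OC`), keeps the shared core and carries one change: 3,4-dihydroxyphenyl in place of 3,5-dichlorophenyl on a double-bonded chain carbon bound to a double-bonded ring carbon.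

Among the measured compounds shown here, three measured steps bear on this position, and all of them exchange one halogenated phenyl group for another. These are an at least 1.6-fold lower number from compound 1 to compound 3 (0.20 log units; that floor lies within the scatter) and an at least 1.6-fold lower number from compound 2 to compound 3 (0.20 log units; that floor lies within the scatter), both known only as floors, and a step that the two limits leave unreadable from compound 1 to compound 2, which has no readable size. For the measured compounds named here, no measured compound carries a hydroxyl group, so the direction of this change in this assay remains open. No step beyond the scatter is expected, though the uncertainty is wide.

In this assay the estimated value for compound 4 is 10000 nM, with an expected range of 3000 nM to 20000 nM. The expected size is a 1.3-fold lower number from compound 3 to compound 4 (0.10 log units; within the scatter).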

Compound 4, half-maximal inhibitory concentration: > 20000 nM
Compound 4: only a limit was reported; the forecaster's own chance of this, stated with the estimate: 25%; middle value at least 2.0-fold (0.30 log units) from the limit.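

With 3,4-dihydroxyphenyl, this position on a double-bonded chain carbon bound to a double-bonded ring carbon now carries a group without halogen, and in this assay the exchange for 3,5-dichlorophenyl gives an at least 1.6-fold higher number from compound 3 to compound 4 (0.20 log units; that floor lies within the scatter). Among the compounds shown here, the result for compound 4 is a limit and not a number, so the hydroxyl groups yield no readable value, and compound 3 remains the only compound with one. The steps to compound 4 from compound 1 and from compound 2 cannot be read, and the compounds cannot be ordered because nearly all the results sit at one limit: the limit of > 20000 nM in this assay, at which 3 of the 4 values shown sit.

From the compounds shown here alone, how far the true values of compound 1, compound 2 and compound 4 lie from that limit stays open. Also open, going by these compounds, is how a phenyl group bearing an amine or a carboxylic acid would read in this assay.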